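Nitro in Place of Hydroxy on the Shared Core

The source may report more compounds than this note shows. Statements on the series, on what has been measured and on what is new or still open speak of the compounds shown alone.

For the measured compounds named here, compound 1 `Oc1cccc(/C=C/C[C@H]2C[C@@H]([C@@H](O)c3ccccc3)CO[C@@H]2c2ccccc2)c1` gives 18600 nM in a functional assay on HeLa cells (Homo sapiens) for cytotoxicity, read by WST assay, with a stated time of 48 h (on this read-out lower numbers stand for stronger inhibition and higher numbers for weaker inhibition), the only number among the three values shown. Compound 2 `COc1ccc(/C=C/C[C@@H]2C[C@@H]([C@@H](OC)c3ccc(OC)c(OC)c3)CO[C@H]2c2ccc(OC)c(OC)c2)cc1OC` sits at the assay limit > 100000 nM in this assay. Compound 3 `COc1ccc(/C=C/C[C@@H]2C[C@@H]([C@@H](OC(C)=O)c3ccc(OC)c(OC)c3)CO[C@H]2c2ccc(OC)c(OC)c2)cc1OC` likewise sits at the limit > 100000 nM in this assay. Going by the values given here, the one measured step, a step that the two limits leave unreadable from compound 2 to compound 3, is unreadable due to the limit of > 100000 nM in this assay, at which 2 of the 3 values shown sit, and it concerns an oxygen on a saturated carbon, not the aromatic ring changed here. Compound 4 `O=[N+]([O-])c1cccc(/C=C/C[C@H]2C[C@@H]([C@@H](O)c3ccccc3)CO[C@@H]2c2ccccc2)c1` differs from compound 1 by nitro in place of hydroxy on an aromatic carbon. Among the compounds with values here, no measured step bears on this change, so compound 4 is expected to stay near compound 1, a step of a 1.1-fold higher number from compound 1 to compound 4 (0.03 log units; within the scatter) within the scatter. Compound 4 is therefore estimated at 20000 nM, ranging from 5000 nM to 80000 nM.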

Compound 4, half-maximal inhibitory concentration: 7850 nM
Beside the measured number, compound 4's estimate is 2.5-fold (0.41 log units) above it, and the stated range covers the measured number.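

Nitro in place of hydroxy on the aromatic carbon gives a 2.4-fold lower number from compound 1 to compound 4 (0.37 log units; beyond the scatter) in this assay, the first step on the shared core that can be read as a size. The hydroxy group, with its hydrogen-bond donor, is therefore not required for a measurable value here, and the number moves beyond the scatter when nitro takes its place. Nothing shown here accounts for the size or direction of this step.

The compounds shown leave open whether an amine or a carboxylic acid on the same aromatic carbon would shift the number further. They also leave open whether nitro would give a similar step on the other aromatic rings of the shared core.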